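Added chloro on the aryl triazole of compound 2

The source may hold more compounds than are shown below. What is called first, only, known or untested is meant among the compounds shown, and "the series" means these compounds.

Two compounds of the series carry a measurement. In a functional assay on MDA-MB-231 cells (Homo sapiens) for cytotoxicity, read by MTT assay, with a stated time of 48 h (on this read-out lower numbers stand for stronger inhibition and higher numbers for weaker inhibition), compound 1 `CCCCn1cc(CO[C@H]2CC(=O)[C@@H]3OC[C@H]2O3)nn1` gives 27900 nM and compound 2 `O=C1C[C@H](OCc2cn(-c3ccccc3Cl)nn2)[C@H]2CO[C@@H]1O2` gives 26400 nM; the two numbers lie within the scatter of each other, as a 1.1-fold lower number from compound 1 to compound 2 (0.02 log units; within the scatter) shows. Compound 3 `O=C1C[C@H](OCc2cn(-c3cccc(Cl)c3Cl)nn2)[C@H]2CO[C@@H]1O2` differs from compound 2 by chloro in place of hydrogen on an aromatic carbon. Going by the values given here, no measured step touches an added chloro on this ring; the single step, a 1.1-fold lower number from compound 1 to compound 2 (0.02 log units; within the scatter), only shows that exchanging the group on the aromatic nitrogen left the read-out unchanged. The expected step is therefore a 1.1-fold lower number from compound 2 to compound 3 (0.04 log units; within the scatter), none beyond the scatter. For compound 3 the estimate is 24000 nM, range 9000 nM to 60000 nM.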

Compound 3, half-maximal inhibitory concentration: 26000 nM
Compound 3: the middle estimate sits 1.1-fold (0.03 log units) below what was measured, within the range that was stated.
By their numbers in this assay, from the lowest: compounds 3, 2 and 1 (each within the scatter of the next).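

Chloro in place of hydrogen on an aromatic carbon, ortho to a chloro group, is now read directly in this assay: a 1.0-fold lower number from compound 2 to compound 3 (0.01 log units; within the scatter) places the 2,3-dichlorophenyl compound within the scatter of its 2-chlorophenyl partner. The step to butyl, a 1.1-fold lower number from compound 1 to compound 3 (0.03 log units; within the scatter), likewise stays within the scatter, so all three compounds remain inseparable on this read-out. No evidence on the cause of these results is available.

From the compounds shown here alone, whether an amine or a carboxylic acid on this ring would separate from the chloro compounds remains open. Going by these compounds, a longer chain on the aromatic nitrogen is equally open.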